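Saturating the chain: from a succinate-type acid to its unsaturated counterpart

The compounds below may be only part of what the source reports. "The series", "measured", "known", "first", "only" and "open" are said of these compounds alone.

Compound 1 `CCOC(=O)CCC(=O)NC[C@H]1O[C@@H](n2cc(F)c(=O)[nH]c2=O)C[C@@H]1O` bears an ethyl ester at the end of the chain that is joined to the shared core through an amide. In a functional assay on 791T cells for cytotoxicity against 791T cell line (Homo sapiens) (a higher number here means a weaker inhibitor, a lower number a stronger inhibitor), compound 1 gives only a limit, > 100 ug/mL. Compound 2 `O=C(O)CCC(=O)NC[C@H]1O[C@@H](n2cc(F)c(=O)[nH]c2=O)C[C@@H]1O` carries the free acid instead. In this assay compound 2 also gives only a limit, > 100 ug/mL. Among the compounds with values here, the step that the two limits leave unreadable from compound 1 to compound 2, hydrogen in place of ethyl on an oxygen next to a carbonyl group, is consequently of unreadable size, and the only evidence gathered so far is the limit of > 100 ug/mL in this assay, at which 2 of the 2 values shown sit.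

Compound 3 `O=C(O)/C=C/C(=O)NC[C@H]1O[C@@H](n2cc(F)c(=O)[nH]c2=O)C[C@@H]1O` differs from compound 2 by 2-carboxyethenyl in place of 2-carboxyethyl on a carbonyl carbon whose other neighbour is an amide-type nitrogen. Within the data shown here, no measured step bears on this change, and the single measured step is itself unreadable, so no direction can be drawn from the data. Compound 2 stands at the limit of this assay. Compound 3 is expected to give 150 ug/mL, with a range from 50 ug/mL to 500 ug/mL. The step that the limit leaves unreadable from compound 2 to compound 3 is expected to stay within the scatter.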

Compound 3, half-maximal inhibitory concentration: 110 ug/mL
Estimate against measurement, compound 3: 1.4-fold (0.13 log units) above; measured number inside the range.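

The steps to compound 3 from compound 1 and from compound 2 in this assay cannot be read, since compound 1 and compound 2 are known only as limits: the limit of > 100 ug/mL in this assay, at which 2 of the 3 values shown sit.

The compounds shown leave open whether 2-carboxyethenyl in place of 2-carboxyethyl on a carbonyl carbon changes the read-out in this assay at all, and in which direction.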